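The source may report more compounds than this note shows. Statements on the series, on what has been measured and on what is new or still open speak of the compounds shown alone.

Of the compounds shown here, three sharing one core have been tested in a functional assay on NCI-H23 cells (Homo sapiens) for inhibition, read by sulforhodamine B assay, with a stated time of 48 h; on this read-out higher numbers stand for weaker inhibition of growth and lower numbers for stronger inhibition of growth. Compound 1, `Nc1cc(N)c2nc(-c3ccccc3)c(NCc3ccc(Cl)c(Cl)c3)nc2c1`, gives 14100 nM in this assay. Compound 2, `CCOC(=O)[C@H](CCC(=O)O)NC(=O)c1ccc(Sc2nc3cc(N)cc(N)c3nc2-c2ccccc2)cc1`, gives 11700 nM in this assay, and compound 3, `COc1cc(CNc2nc3cc(N)cc(N)c3nc2-c2ccccc2)cc(OC)c1OC`, gives 8710 nM in this assay. Compound 1 carries the highest of the three numbers, but its gaps to compound 2 and to compound 3 both fall within the usual scatter of repeated measurements, so the three cannot be placed in order of strength on these values alone.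

The compound now in question is compound 4, `Nc1cc(N)c2nc(-c3ccccc3)c(NCc3ccc(F)cc3)nc2c1`. It differs from compound 1 in one place: 4-fluorophenyl in place of 3,4-dichlorophenyl on a saturated chain carbon bound to a nitrogen on an aromatic ring. Going by the values given here, no measured pair of compounds here shows what such a change does in this assay, so the expectation rests on the values alone. Since all three measured numbers sit close together, compound 4 is expected to stay in the same region, with a step of a 1.3-fold higher number from compound 1 to compound 4 (0.11 log units; within the scatter) that need not exceed the scatter. Compound 4 is estimated at 18000 nM in this assay, with a range from 6000 nM to 50000 nM.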

Compound 4, concentration for 50% growth inhibition: 2400 nM
For compound 4 the middle estimate is 7.5-fold (0.88 log units) above the measured one; measured number outside the range, below it.
By their numbers in this assay, from the lowest: compound 4; then compounds 3, 2 and 1 (each within the scatter of the next).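

The exchange of 3,4-dichlorophenyl for 4-fluorophenyl on a saturated chain carbon bound to a nitrogen on an aromatic ring gives a clear change in the read-out (this assay) with a 5.9-fold lower number from compound 1 to compound 4 (0.77 log units; beyond the scatter), and the lower number stands for stronger inhibition of growth. Going by these compounds alone, the earlier compounds offered no comparison in which only one place differed, so this pair is the first to show that the group at this position can shift the number beyond the usual scatter. No measurement shown here explains the step.

This single exchange removes both chlorines and adds a fluorine at once, so it cannot tell which part of the change matters. From the compounds shown here alone, how a plain phenyl with no halogen, or a phenyl carrying an amine or a carboxylic acid, would behave at this position remains open, as does the effect of a longer chain leading to the ring.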